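Pyrrolidinyl amide in a diarylthiourea series: expected cytotoxicity

The source may report more compounds than this note shows. Statements on the series, on what has been measured and on what is new or still open speak of the compounds shown alone.

Compound 1 `CNC(=O)c1cc(Oc2cccc(NC(=S)Nc3ccc(Cl)cc3Cl)c2)ccn1` gives > 100000 nM in a functional assay on MDA-MB-231 cells (Homo sapiens) for cytotoxicity, read by MTT assay, with a stated time of 48 h (on this read-out lower numbers stand for stronger inhibition and higher numbers for weaker inhibition), a limit of the assay and not a number.
Compound 2 `O=C(NCc1ccccc1)c1cc(Oc2cccc(NC(=S)Nc3ccc(Cl)cc3)c2)ccn1` gives > 100000 nM in this assay, again only a limit.
Compound 3 `CCNC(=O)c1cc(Oc2cccc(NC(=S)Nc3ccc(F)c(F)c3)c2)ccn1` gives > 100000 nM in this assay, also a limit.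

Going by the values given here, compound 3 thus stands at the limit of > 100000 nM in this assay, at which 3 of the 3 values shown sit; none of the three measured compounds yields a number, so no step between measured compounds can be counted. The unmeasured compound 4 `O=C(c1cc(Oc2cccc(NC(=S)Nc3ccc(F)c(F)c3)c2)ccn1)N1CCCC1` differs from compound 3 by pyrrolidin-1-yl in place of ethylamino on a carbonyl carbon. With every measured value sitting at the limit, the expected step is a number no higher from compound 3 to compound 4 (the limit leaves the size open), none beyond the scatter. Compound 4 is therefore estimated at 100000 nM, in a range from 30000 nM to 300000 nM, and is most likely to be reported as a limit rather than a number.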

Compound 4, half-maximal inhibitory concentration: > 100000 nM
Compound 4 was reported as a limit (the forecaster's own chance of this, stated with the estimate: 85%); the middle value sits exactly at the limit.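

The step between compound 3 and compound 4 cannot be read, since both values are only limits of the assay: the limit of > 100000 nM in this assay, at which 4 of the 4 values shown sit.

The compounds shown leave open how pyrrolidin-1-yl and ethylamino on a carbonyl carbon compare, and what in this series would give a measurable number.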